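This account rests on a few compounds, and the source may have more. Where it says the series, first, only, none or still open, it means among the compounds named here.

Measured compounds:
compound 1 `Cc1nc(-c2ccccc2F)c(C(=O)N2CCN(c3cc(Cl)cc(Cl)c3)CC2)o1` with 82.3%
compound 2 `Cc1nc(-c2ccccc2)c(C(=O)N2CCN(c3cccc(C)c3C)CC2)o1` with 29.8%
compound 3 `CCC[C@H](Nc1nc(-c2ccc(NC(=O)NCC)c(OC)c2)ncc1C)c1cccnc1` with 54.6%

The three compounds were tested in an ADME assay (liver) for metabolic stability, with Liver microsome (Homo sapiens) as the target, read by LC-MS, using microsomes, with a stated time of 1 h, tested at 5 uM; a higher number here means that more of the compound is left, a lower number that less of the compound is left. Among them compound 2 has the lowest number; compound 3 is the nearest to it, and already that gap lies beyond the usual scatter, while compound 1 is the furthest from it, again beyond the scatter. Compound 4 `COc1cc(OC)cc(N2CCN(C(=O)c3oc(C)nc3-c3ccccc3)CC2)c1` has not yet been measured in this assay. It differs from compound 2 at one place only: 3,5-dimethoxyphenyl in place of 2,3-dimethylphenyl on an amine nitrogen in a ring. The group that leaves and the group that enters sit on the same amine nitrogen in a ring of the six-membered non-aromatic ring with two nitrogens, and both are single six-membered aromatic rings of carbon only, the entering one carrying two oxygens and two hydrogen-bond acceptors where the leaving one carried none.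

No pair of measured compounds that differ in one place is shown, so nothing in these data sets a size for such a change. The account therefore expects the step of a number 6.2 percentage points higher from compound 2 to compound 4 (within the scatter) to be small and, more likely than not, to stay within the scatter, with a slight lean upward. For compound 4 in this assay the expected value is 36%, with a range from 15% to 62%.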

Compound 4, percent of the compound remaining: 15.8%
Compound 4: middle estimate off by 20.2 percentage points, on the high side; the range from low to high includes it.
By their numbers in this assay, from the lowest: compound 4; then compound 2; then compound 3; then compound 1.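

In this assay the swap of 2,3-dimethylphenyl for 3,5-dimethoxyphenyl on an amine nitrogen in a ring gives a number 14 percentage points lower from compound 2 to compound 4 (beyond the scatter) and so provides the only measured size for a change at this place. It shows that the number here responds to the aromatic group on this nitrogen, even though the leaving and entering groups are both single six-membered aromatic rings of carbon only, and that the entering group with its two oxygens goes with less of the compound left. Nothing shown here offers an explanation for this fall.

On these data alone, it remains open whether the fall goes with the methoxy groups themselves or with where the substituents sit on the aromatic ring, for the step changes both at once, and 3,5-dimethylphenyl or plain phenyl on the same nitrogen would separate the two. Also open, as far as these compounds go, is how a pyridine ring on this nitrogen would read in this assay and whether a step of this size would hold on the core of compound 3 or another core.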